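Methyl for Methoxy: Expecting the Permeability of Compound 4

The source may report more compounds than this note shows. Statements on the series, on what has been measured and on what is new or still open speak of the compounds shown alone.

Compound 1 `COc1ccc(O)c(C(=O)Nc2ccc([N+](=O)[O-])cc2Cl)c1` and compound 2 `Cc1ccc(O)c(C(=O)Nc2ccc([N+](=O)[O-])cc2Cl)c1` differ in a single place: methyl in place of methoxy on an aromatic carbon. In an ADME assay for permeability, using PAMPA (a higher number here means that the compound crosses the layer faster, a lower number that the compound crosses the layer more slowly), compound 1 gives 67.1 10^-6 cm/s, while compound 2 gives 134 10^-6 cm/s, so that the step is a 2.0-fold higher number from compound 1 to compound 2 (0.30 log units; within the scatter). Compound 3 `COc1ccc(NC(=O)c2cc(Cl)ccc2O)cc1` rests on another core; how the two cores differ is not broken down here. In this assay compound 3 gives 81 10^-6 cm/s. Compound 4 `Cc1ccc(NC(=O)c2cc(Cl)ccc2O)cc1` has not yet been measured and differs from compound 3 in one place: methyl in place of methoxy on an aromatic carbon. This is the same kind of change as from compound 1 to compound 2, though the surroundings differ: in compound 1 the group sits meta to a large group and para to a hydroxy group, in compound 3 para to a large group. Because the earlier change gave a 2.0-fold higher number from compound 1 to compound 2 (0.30 log units; within the scatter), the step from compound 3 to compound 4 is expected to be similar, a 1.4-fold higher number from compound 3 to compound 4 (0.15 log units; within the scatter). Compound 4 is therefore expected to give about 115 10^-6 cm/s in this assay, with a likely span from 65 10^-6 cm/s to 200 10^-6 cm/s.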

Compound 4, apparent permeability in the ADME assay: 21 10^-6 cm/s
The estimate for compound 4 lay 5.5-fold (0.74 log units) above the measured number; the measured number lies below the stated range.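

Methyl in place of methoxy did not behave the same way on the two cores in the ADME assay, where compound 3 gives 81 10^-6 cm/s, compound 4 gives 21 10^-6 cm/s, and the new step is a 3.9-fold lower number from compound 3 to compound 4 (0.59 log units; beyond the scatter). Set beside the earlier step, the two results disagree: the same change on two cores in the ADME assay, a 2.0-fold higher number (0.30 log units; within the scatter) from compound 1 to compound 2 and a 3.9-fold lower number (0.59 log units; beyond the scatter) from compound 3 to compound 4, 7.7-fold (0.89 log units) apart, beyond the scatter of two such steps. This shows that the result of this change on the core of compound 1 could not be carried over to the core of compound 3, but it does not show which difference between the cores matters, and a single pair on each core gives no rule for the whole series.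

In a physicochemical assay for solubility (on this read-out higher numbers stand for higher solubility and lower numbers for lower solubility), compound 3 gives 2.8 ug/mL. In the physicochemical assay compound 4 gives < 1 ug/mL, which is a limit of the assay and not a number.

The compounds shown leave open how an amine, a carboxylic acid or a longer chain such as ethoxy would compare at this place on either core in the ADME assay. They also leave open what the same change from methoxy to methyl would do on a third core.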